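Changing the nitrogen substituent on a weak Bcl-2 binder

The compounds below may be only part of what the source reports. "The series", "measured", "known", "first", "only" and "open" are said of these compounds alone.

Compound 1, `O=C(Nc1ccc(O)c(C(=O)O)c1)c1ccc(/C=C2\SC(=S)N(c3ccccc3)C2=O)cc1`, in an assay on isolated protein for inhibition of Apoptosis regulator Bcl-2 (Homo sapiens), read by fluorescence polarization; on this read-out lower numbers stand for stronger inhibition and higher numbers for weaker inhibition: > 10000 nM, which is a limit of the assay rather than a number.
Compound 2, `Cc1ccc(N2C(=O)/C(=C/c3ccc(OCc4ccc(C(=O)O)cc4)cc3)SC2=S)cc1`, in this assay: > 10000 nM, again a limit and not a number.

Compound 2 therefore stands only at a limit; both values shown sit at the limit of > 10000 nM in this assay, at which 2 of the 2 values shown sit. Compound 3, `O=C(O)c1ccc(COc2ccc(/C=C3\SC(=S)N(Cc4ccc(F)cc4)C3=O)cc2)cc1`, differs from it in one place: 4-fluorobenzyl in place of 4-methylphenyl on an amide-type nitrogen in a ring. Within the data shown here, no measured step connects these two, so the change from compound 2 to compound 3 is estimated as a step that the limit leaves unreadable from compound 2 to compound 3, with no direction expected beyond the scatter. Compound 3 is expected to give 15000 nM, in the range 3000 nM to 60000 nM.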

Compound 3, inhibition constant: > 10000 nM
Compound 3: only a limit was reported; the forecaster's own chance of this, stated with the estimate: 75%; the middle value lies beyond the limit too.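

Compound 2 and compound 3 both sit at a limit, so no step can be read for 4-fluorobenzyl in place of 4-methylphenyl: the limit of > 10000 nM in this assay, at which 3 of the 3 values shown sit.

The compounds shown leave open how compound 2 and compound 3 truly compare, and which change on the nitrogen would give a readable number.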